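A Trimethoxyphenyl Swap on an Inactive Compound

The source may hold more compounds than are shown below. What is called first, only, known or untested is meant among the compounds shown, and "the series" means these compounds.

Measured so far in a functional assay on EKVX cells (Homo sapiens) for inhibition; a lower number here means a stronger inhibitor of growth, a higher number a weaker inhibitor of growth:
- compound 1 `COc1cc(/C=C/C(=O)c2cccc(-n3cc(-c4ccc(Cl)cc4)[nH]c3=O)c2)cc(OC)c1OC`: "not active" (no number reported)
- compound 2 `COc1cc(/C=C/C(=O)c2cccc(-n3cc(-c4ccccc4)[nH]c3=O)c2)ccc1O`: 3900 nM
- compound 3 `O=C(/C=C/c1cccc(O)c1)c1cccc(-n2cc(-c3ccccc3)[nH]c2=O)c1`: 15600 nM

Compound 1 has no place on the numerical scale: in this assay compound 1 is reported as "not active" (no number reported), with no figure attached. Compound 4 `COc1cc(/C=C/C(=O)c2cccc(-n3cc(-c4cc(OC)c(OC)c(OC)c4)[nH]c3=O)c2)cc(OC)c1OC` is the next to be tested. It changes compound 1 at one place: 3,4,5-trimethoxyphenyl in place of 4-chlorophenyl on an aromatic carbon. The new 3,4,5-trimethoxyphenyl stands where 4-chlorophenyl stood, on an aromatic carbon of a five-membered aromatic ring with 2 nitrogen.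

Among the compounds with values here, only one measured step is available, a 4.0-fold higher number from compound 2 to compound 3 (0.60 log units; beyond the scatter). It replaces 4-hydroxy-3-methoxyphenyl with 3-hydroxyphenyl on a double-bonded chain carbon, so it does not touch the place changed here and offers only a rough sense of how far a single change can move this series. Compound 1 has no number to step from, so neither a size nor a direction can be set for this change. With compound 1 at "not active" (no number reported), a weak result is expected, perhaps no number at all. The estimate for compound 4 is 15000 nM, with an expected range of 4000 nM to 50000 nM.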

Compound 4, concentration for 50% growth inhibition: 9470 nM
Compound 4: middle estimate off by 1.6-fold (0.20 log units), on the high side; the range from low to high includes it.
By their numbers in this assay, from the lowest: compound 2; then compounds 4 and 3 (each within the scatter of the next).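

In this assay compound 1 gives "not active" (no number reported) while compound 4 gives 9470 nM and so no step can be read between the two. The compounds shown leave open how far 3,4,5-trimethoxyphenyl and 4-chlorophenyl differ on one shared core when both compounds carry a number. No further data bear on this result.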